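The source may report more compounds than this note shows. Statements on the series, on what has been measured and on what is new or still open speak of the compounds shown alone.

In an assay on cells for agonist activity at vitamin D3 receptor (Homo sapiens), with a stated time of 96 h (on this read-out higher numbers stand for an effect only at larger amounts of compound and lower numbers for an effect already at smaller amounts), three compounds have been measured: compound 1 `CCN(CC)CCNC(=O)c1ccc(C(CC)(CC)c2ccc(OCCC(O)(CC)CC)c(C)c2)n1CC` gives 2.3 nM; compound 2 `CCn1c(C(=O)NCCN)ccc1C(CC)(CC)c1ccc(OCCC(O)(CC)CC)c(C)c1` gives 156 nM; compound 3 `CCn1c(C(=O)Nc2cccc(C(F)(F)F)c2)ccc1C(CC)(CC)c1ccc(OCCC(O)(CC)CC)c(C)c1` gives 5900 nM.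

Compound 3 stands highest of the three: the steps of a 2600-fold higher number from compound 1 to compound 3 (3.41 log units; beyond the scatter) and a 38-fold higher number from compound 2 to compound 3 (1.58 log units; beyond the scatter) are both large and beyond the scatter. Compound 4 `CCC(C)C(NC(=O)c1ccc(C(CC)(CC)c2ccc(OCCC(O)(CC)CC)c(C)c2)n1CC)C(=O)O` differs from compound 3 by 1-carboxy-2-methylbutyl in place of 3-(trifluoromethyl)phenyl on an amide-type nitrogen. The two measured steps bear on this change, since both put the aryl group onto the amide nitrogen in place of a chain and both raised the number strongly; the reverse direction, back to a chain, is therefore expected to lower the number. Compound 4 carries no amine, so the full return to compound 1 is not expected; the step is estimated at a 15-fold lower number from compound 3 to compound 4 (1.17 log units; beyond the scatter). Compound 4 is estimated at 400 nM, within 40 nM to 4000 nM.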

Compound 4, half-maximal effective concentration: 860 nM
Compound 4: middle estimate off by 2.2-fold (0.33 log units), on the low side; low and high end bracket the measured number.
By their numbers in this assay, from the lowest: compound 1; then compound 2; then compound 4; then compound 3.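

On the amide-type nitrogen, 1-carboxy-2-methylbutyl recovers only part of what 3-(trifluoromethyl)phenyl loses, with a 6.9-fold lower number from compound 3 to compound 4 (0.84 log units; beyond the scatter) but still a 370-fold higher number from compound 1 to compound 4 (2.57 log units; beyond the scatter). It also stands above the 2-aminoethyl chain, with a 5.5-fold higher number from compound 2 to compound 4 (0.74 log units; beyond the scatter), so among these compounds a chain in itself does not restore the low number of compound 1. Nothing available here explains this order.

Left open is whether the carboxylic acid or the branched carbon chain sets the number of compound 4, which a 2-methylbutyl group or a methyl ester would separate. Also open, as far as these compounds go, is how a longer chain ending in diethylamino would compare with compound 1.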